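The compounds below may be only part of what the source reports. "The series", "measured", "known", "first", "only" and "open" are said of these compounds alone.

Measured compounds:
Compound 1 `C[C@H](NC(=O)C(=O)Nc1ccccc1)C(=O)N[C@@H](CC(=O)O)C(=O)COc1c(F)c(F)cc(F)c1F` gives 670 nM in a functional assay on Jurkat cells (Homo sapiens) for inhibition; a higher number here means a weaker inhibitor, a lower number a stronger inhibitor.
Compound 2 `C[C@H](NC(=O)C(=O)Nc1ccccc1Cl)C(=O)N[C@@H](CC(=O)O)C(=O)COc1c(F)c(F)cc(F)c1F` gives 64 nM in this assay.
Compound 3 `C[C@H](NC(=O)C(=O)Nc1ccccc1Br)C(=O)N[C@@H](CC(=O)O)C(=O)COc1c(F)c(F)cc(F)c1F` gives 75 nM in this assay.

Among these three, compound 1 has the highest number in this assay; both other compounds sit well below it, beyond the scatter, so compound 1 is the weakest inhibitor of the set. Compound 4 `C[C@H](NC(=O)C(=O)Nc1ccccc1-c1ccc[nH]1)C(=O)N[C@@H](CC(=O)O)C(=O)COc1c(F)c(F)cc(F)c1F` differs from compound 1 in one place: 1H-pyrrol-2-yl in place of hydrogen on an aromatic carbon. The same place on the ring has been changed twice before: a 10-fold lower number from compound 1 to compound 2 (1.02 log units; beyond the scatter) and an 8.9-fold lower number from compound 1 to compound 3 (0.95 log units; beyond the scatter), two steps of closely matching size, while a 1.2-fold higher number from compound 2 to compound 3 (0.07 log units; within the scatter). Both measured steps show that filling this place with a group gives a clearly stronger inhibitor. Among the compounds with values here, a pyrrolyl ring is not a halogen, and no measured compound carries a ring at this place, so how far the gain carries over is uncertain. The expectation for compound 4 is therefore a moderate downward step, a 4.5-fold lower number from compound 1 to compound 4 (0.65 log units; beyond the scatter). For compound 4 the expected value in this assay is 150 nM, with a range from 40 nM to 600 nM.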

Compound 4, half-maximal inhibitory concentration: 56 nM
For compound 4 the middle estimate is 2.7-fold (0.43 log units) above the measured one; the range from low to high includes it.
By their numbers in this assay, from the lowest: compounds 4, 2 and 3 (each within the scatter of the next); then compound 1.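

In this assay the step is a 12-fold lower number from compound 1 to compound 4 (1.08 log units; beyond the scatter) for 1H-pyrrol-2-yl, a whole five-membered aromatic ring, so the gain at this place is not limited to a single halogen atom. Putting this ring in place of a halogen gives a 1.3-fold lower number from compound 3 to compound 4 (0.13 log units; within the scatter) and a 1.1-fold lower number from compound 2 to compound 4 (0.06 log units; within the scatter), so compounds 2, 3 and 4 cannot be told apart in this assay, despite the large difference in the size of their groups. Nothing available explains why such different groups give matching numbers.

Going by these compounds, whether the hydrogen on the ring nitrogen matters remains open, and a 1-methylpyrrol-2-yl or plain phenyl group at this place would address that. A methyl group or an amine at this place would show whether the gain extends to other small groups.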